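The source may hold more compounds than are shown below. What is called first, only, known or untested is meant among the compounds shown, and "the series" means these compounds.

For the measured compounds named here, three amides on the shared core have numbers so far in a functional assay on A549 cells (Homo sapiens) for inhibition, read by MTT assay, with a stated time of 72 h (on this read-out higher numbers stand for weaker inhibition and lower numbers for stronger inhibition), on this series. Compound 1 `C=CC(=O)Nc1cc(Nc2nc3c(c(-c4cn(C)c5ccccc45)n2)CS(=O)(=O)CC3)c(OC)cc1N(C)CCN(C)C` gives 8690 nM as its reading. Compound 2 `C=C(Cl)C(=O)Nc1cc(Nc2nc3c(c(-c4cn(C)c5ccccc45)n2)CS(=O)(=O)CC3)c(OC)cc1N(C)CCN(C)C` gives 881 nM and compound 3 `CC/C=C\C(=O)Nc1cc(Nc2nc3c(c(-c4cn(C)c5ccccc45)n2)CS(=O)(=O)CC3)c(OC)cc1N(C)CCN(C)C` gives 1350 nM as theirs. Compound 3 sits close to compound 2, with a 1.5-fold higher number from compound 2 to compound 3 (0.19 log units; within the scatter) as the gap, and well away from compound 1.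

Compound 4 `CCC/C=C\C(=O)Nc1cc(Nc2nc3c(c(-c4cn(C)c5ccccc45)n2)CS(=O)(=O)CC3)c(OC)cc1N(C)CCN(C)C` differs from compound 3 by methyl in place of hydrogen on a saturated chain carbon, two bonds along the chain from a double-bonded chain carbon with methyl in place of hydrogen on a saturated chain carbon, two bonds along the chain from a double-bonded chain carbon. But-1-en-1-yl thereby becomes pent-1-en-1-yl.

Going by the values given here, no measured step is this same change. The closest is a 6.4-fold lower number from compound 1 to compound 3 (0.81 log units; beyond the scatter) for but-1-en-1-yl in place of vinyl on a carbonyl carbon. The step of a 9.9-fold lower number from compound 1 to compound 2 (0.99 log units; beyond the scatter) for chloro in place of hydrogen is of similar modest size, and both alter the group on the carbonyl carbon more directly than the new change does. No step beyond the scatter is therefore expected in this assay here. The estimate means a 1.0-fold higher number from compound 3 to compound 4 (0.02 log units; within the scatter) as the expected step. Compound 4 is estimated at 1400 nM with an expected range from 550 nM to 3500 nM as its bounds.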

Compound 4, half-maximal inhibitory concentration: 57 nM
Compound 4: the middle estimate sits 25-fold (1.39 log units) above what was measured; measured number below the stated range.
By their numbers in this assay, from the lowest: compound 4; then compounds 2 and 3 (each within the scatter of the next); then compound 1.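

In this assay the chain on the carbonyl carbon remains responsive well away from the carbonyl: methyl in place of hydrogen on a saturated chain carbon, two bonds along the chain from a double-bonded chain carbon, gives a 24-fold lower number from compound 3 to compound 4 (1.37 log units; beyond the scatter) and thereby turns but-1-en-1-yl into pent-1-en-1-yl. This single added carbon moves the number further than either earlier step from vinyl, and pent-1-en-1-yl also stands clear of 1-chloroethenyl, with a 15-fold lower number from compound 2 to compound 4 (1.19 log units; beyond the scatter). Compounds 2 and 3, by contrast, could not be separated. Across the whole change from vinyl to pent-1-en-1-yl the series shows a 150-fold lower number from compound 1 to compound 4 (2.18 log units; beyond the scatter) and a fall in the number at each added stage of the chain, while the data at hand offer no explanation for the size of the last stage.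

Going by these compounds, whether the trend continues to a longer chain such as hex-1-en-1-yl, or stops there, remains open. Also open, on these data alone, is whether the gain depends on a purely carbon chain end, which a terminal dimethylamino group or a methoxy group on the pent-1-en-1-yl chain would test in this assay on the same core.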